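Ester for trifluoromethyl on a chlorosulfamoyl benzamide

The source may report more compounds than this note shows. Statements on the series, on what has been measured and on what is new or still open speak of the compounds shown alone.

Measured compounds:
compound 1 `COc1cccc(CNC(=O)c2ccc(Cl)c(S(N)(=O)=O)c2)c1`, 18600 nM
compound 2 `NS(=O)(=O)c1cc(C(=O)Nc2ccc(C(F)(F)F)cc2)ccc1Cl`, 10900 nM

In a functional assay on HCT-116 cells (Homo sapiens) for inhibition, read by MTT assay, with a stated time of 48 h (on this read-out lower numbers stand for stronger inhibition and higher numbers for weaker inhibition), compound 2 gives 10900 nM, and compound 1 gives 18600 nM; these two values lie within the scatter of each other, so neither compound can be called the stronger inhibitor. Compound 3 `CC(C)(C)OC(=O)c1ccc(NC(=O)c2ccc(Cl)c(S(N)(=O)=O)c2)cc1` is not yet measured. It differs from compound 2 by tert-butoxycarbonyl in place of trifluoromethyl on an aromatic carbon. Among the measured compounds shown here, no step between measured compounds in this assay is available to set a scale for such a change. On the two values shown, the step from compound 2 to compound 3 is expected to be small, a 1.4-fold higher number from compound 2 to compound 3 (0.14 log units; within the scatter), and not beyond the scatter. Compound 3 is therefore estimated at 15000 nM, in the range from 5000 nM to 45000 nM.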

Compound 3, half-maximal inhibitory concentration: 690 nM
Compound 3: the middle estimate sits 22-fold (1.34 log units) above what was measured; the measured number lies below the stated range.
By their numbers in this assay, from the lowest: compound 3; then compounds 2 and 1 (each within the scatter of the next).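

In this assay the place para to a large group proves far from indifferent to what it carries: tert-butoxycarbonyl in place of trifluoromethyl gives a 16-fold lower number from compound 2 to compound 3 (1.20 log units; beyond the scatter), a step well beyond the scatter. Among the compounds shown here, the earlier pair of compounds offered no such step, and the values of compound 1 and compound 2 lay within the scatter of each other. Nothing measured here accounts for the size of this change. As far as these compounds go, it remains open whether the whole ester is needed at this place or only part of it. A carboxylic acid or a methyl ester at the same place would help separate the two.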